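Lengthening the Chain on the Ring Amine: Compound 3 to 4

The source may hold more compounds than are shown below. What is called first, only, known or untested is meant among the compounds shown, and "the series" means these compounds.

Three compounds share one core. Compound 1 `CCOCCn1c(N2CCN(C)CC2)nc2ccccc21` gives 10 nM in a functional assay on ileum for inhibition of histamine H1 receptor (Cavia porcellus); on this read-out lower numbers stand for stronger inhibition and higher numbers for weaker inhibition. Compound 2 `C=CCOCCn1c(N2CCCN(C)CC2)nc2ccccc21` gives 10 nM in this assay. Compound 3 `CCCN1CCN(c2nc3ccccc3n2CCOCC)CC1` gives 16 nM in this assay, the largest of the three numbers shown, though both others lie within the scatter of it. The one step among these, a 1.6-fold higher number from compound 1 to compound 3 (0.20 log units; within the scatter), moved the number by less than the scatter.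

Compound 4 `CCCCN1CCN(c2nc3ccccc3n2CCOCC)CC1` differs from compound 3 by methyl in place of hydrogen on a saturated chain carbon, three bonds along the chain from an amine nitrogen in a ring. For the measured compounds named here, the only step that bears on this, a 1.6-fold higher number from compound 1 to compound 3 (0.20 log units; within the scatter), lengthened the same chain and stayed within the scatter, so no step beyond the scatter is expected in this assay. The expected step is a 1.3-fold higher number from compound 3 to compound 4 (0.10 log units; within the scatter). Compound 4 is therefore estimated at 20 nM, with a range from 8 nM to 50 nM.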

Compound 4, half-maximal inhibitory concentration: 15 nM
Beside the measured number, compound 4's estimate is 1.3-fold (0.12 log units) above it, within the range that was stated.
By their numbers in this assay, from the lowest: compounds 1, 2, 4 and 3 (each within the scatter of the next).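

The chain on the ring amine now reaches butyl, and this assay still does not separate it from propyl, with a 1.1-fold lower number from compound 3 to compound 4 (0.03 log units; within the scatter). Over the whole span from the methyl group, the read-out shows a 1.5-fold higher number from compound 1 to compound 4 (0.18 log units; within the scatter), so among these compounds lengthening this chain has produced no step beyond the scatter. No evidence is available that accounts for this result.

Still open, as far as these compounds go, is whether a chain longer than butyl would stay within the scatter. Also open, from the compounds shown here alone, is what a chain ending in an amine or a carboxylic acid would do at this position.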